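Adding a methylcarbamoyl group to compound 2

This account rests on a few compounds, and the source may have more. Where it says the series, first, only, none or still open, it means among the compounds named here.

The study measures a physicochemical assay for solubility, at pH 6 (a higher number here means a more soluble compound, a lower number a less soluble compound), across a set of three related compounds. Compound 1 `N#Cc1ccc(-c2cc(-c3ccc(C(N)=O)cc3)cc(-c3cncs3)n2)cc1` gives 64000 nM in this assay. Compound 2 `N#Cc1ccc(-c2cc(-c3ccccc3)cc(-c3ccco3)n2)cc1` gives 2000 nM and stands lowest of the two numbers that are reported, with compound 1 sitting markedly higher, a gap well beyond the usual scatter. Compound 3 `c1coc(-c2cc(-c3nccs3)cc(-c3ccc(-c4nccs4)cc3)n2)c1` is reported only as a limit of this assay, (the limit of < 1000 nM in this assay, at which 1 of the 3 values shown sits), namely < 1000 nM, and not as a number.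

Compound 4 `CNC(=O)c1ccc(-c2cc(-c3ccc(C#N)cc3)nc(-c3ccco3)c2)cc1` has not yet been measured. It differs from compound 2 by a single change, (methylcarbamoyl in place of hydrogen on an aromatic carbon). Going by the values given here, no pair of measured compounds differs in exactly one place, so no measured step sets the size of this change. Still, compound 1, which carries a carbamoyl group of its own, gives 64000 nM, and on that basis the step from compound 2 to compound 4 is expected to be a rise in this assay, of a 5.0-fold higher number from compound 2 to compound 4 (0.70 log units; beyond the scatter). Compound 4 is therefore estimated at 10000 nM, with a range from 3000 nM to 40000 nM.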

Compound 4, solubility: 25000 nM
Compound 4: the middle estimate sits 2.5-fold (0.40 log units) below what was measured; the range from low to high includes it.
By their numbers in this assay, from the lowest: compound 2; then compound 4; then compound 1. At a limit, below all of these: compound 3.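

In this assay, the change of methylcarbamoyl in place of hydrogen, on an aromatic carbon para to a large group, gives a large rise, a 13-fold higher number from compound 2 to compound 4 (1.10 log units; beyond the scatter), with the rest of the compound unchanged. Going by these compounds alone, the earlier compounds differ from one another in more than one place, so this is the first step that ties a change in this read-out to this position alone. Nothing shown gives a cause for the rise.

Going by these compounds, it remains open whether a carboxylic acid, an amine or a longer chain on the amide nitrogen would give a step of similar size at this position. On these data alone, it is also open whether the same change would give a comparable rise on compounds that differ from compound 2 elsewhere in the structure.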